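The source may report more compounds than this note shows. Statements on the series, on what has been measured and on what is new or still open speak of the compounds shown alone.

The three measured compounds share one core. Compound 1 `Cn1nc(-c2nnc(-c3ccc(O)cc3)o2)c2ccccc21` carries a 4-hydroxyphenyl, compound 2 `Cn1nc(-c2nnc(-c3ccccc3Br)o2)c2ccccc21` a 2-bromophenyl, and compound 3 `Cc1ccc(-c2nnc(-c3nn(C)c4ccccc34)o2)cc1` a 4-methylphenyl. In an ADME assay on L02 cells (Homo sapiens) for cytotoxicity, read by MTT assay, with a stated time of 72 h (on this read-out higher numbers stand for weaker inhibition and lower numbers for stronger inhibition), compound 1 reaches only a limit of the assay, > 100000 nM. In this assay compound 2 gives 89000 nM. Compound 3 likewise stands only at a limit, > 100000 nM, so it sits at the limit of > 100000 nM in this assay, at which 2 of the 3 values shown sit, and no number is known for it. The change to compound 4 `Cn1nc(-c2nnc(-c3ccc(Cl)cc3)o2)c2ccccc21` is chloro in place of methyl on an aromatic carbon. Among the compounds with values here, the steps that bear on it are a step that the two limits leave unreadable from compound 1 to compound 3 and an at least 1.1-fold higher number from compound 2 to compound 3 (0.05 log units; that floor lies within the scatter); the first cannot be read and the second has a floor within the scatter, so no step beyond the scatter is expected. Compound 4 is therefore expected to stand at 100000 nM, between 50000 nM and 200000 nM. This expectation amounts to a number no higher from compound 3 to compound 4 (the limit leaves the size open).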

Compound 4, half-maximal inhibitory concentration: > 100000 nM
Compound 4: only a limit was reported (the forecaster's own chance of this, stated with the estimate: 70%); the middle value lies on the limit itself.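

In this assay the chloro of compound 4 ends at a limit, like the methyl of compound 3 and the hydroxy of compound 1, so three different groups para to a large group now give no number: the limit of > 100000 nM in this assay, at which 3 of the 4 values shown sit. Within the data shown here, the one readable step is an at least 1.1-fold higher number from compound 2 to compound 4 (0.05 log units; that floor lies within the scatter). The steps to compound 4 from compound 1 and from compound 3 cannot be read.

Going by these compounds, whether an amine or a carboxylic acid on this aromatic carbon would give a number stays open. So does how compound 1, compound 3 and compound 4 would compare beyond the limit.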